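This account rests on a few compounds, and the source may have more. Where it says the series, first, only, none or still open, it means among the compounds named here.

For the measured compounds named here, in a functional assay on GTL 16 cells for antiproliferative activity against GTL 16 cell line (Homo sapiens), read by CCK-8 assay, with a stated time of 72 h (a higher number here means a weaker inhibitor, a lower number a stronger inhibitor), compound 1 `Cc1ccc(C(=O)Nc2cccc(-c3oc4cc(-c5ccc(F)cc5)ccc4c(=O)c3O)c2)cc1` gives 12900 nM, the second highest of the three numbers measured so far. Compound 2 `Cc1cccc(C(=O)Nc2cccc(-c3oc4cc(-c5ccc(F)cc5)ccc4c(=O)c3O)c2)c1` gives 10900 nM, and compound 3 `CCc1ccc(C(=O)Nc2cccc(-c3oc4cc(-c5ccc(F)cc5)ccc4c(=O)c3O)c2)cc1` gives 24600 nM. The measured steps are small: a 1.2-fold lower number from compound 1 to compound 2 (0.07 log units; within the scatter), a 1.9-fold higher number from compound 1 to compound 3 (0.28 log units; within the scatter) and a 2.3-fold higher number from compound 2 to compound 3 (0.35 log units; beyond the scatter), only the last reaching beyond the scatter, and modestly.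

Compound 4 `O=C(Nc1cccc(-c2oc3cc(-c4ccc(F)cc4)ccc3c(=O)c2O)c1)c1ccc([N+](=O)[O-])cc1` differs from compound 1 by nitro in place of methyl on an aromatic carbon. Going by the values given here, no measured step exchanges methyl for nitro, or for any group other than a further carbon, so none bears directly on this change. What the measured steps do show is that the group on the ring bound to the carbonyl carbon, whether 4-methylphenyl, 3-methylphenyl or 4-ethylphenyl, moves the number only a little. On that basis no step beyond the scatter is expected in this assay, in either direction, though the lack of any nitro precedent leaves the range wide. Compound 4 is therefore estimated at 12000 nM, between 4000 nM and 40000 nM. That expectation corresponds to a 1.1-fold lower number from compound 1 to compound 4 (0.03 log units; within the scatter).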

Compound 4, half-maximal inhibitory concentration: 18200 nM
Estimate against measurement, compound 4: 1.5-fold (0.18 log units) below; the measured number falls inside the stated range.
By their numbers in this assay, from the lowest: compounds 2, 1, 4 and 3 (each within the scatter of the next, the first and the last beyond it).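

In this assay this position, the aromatic carbon para to a large group, now carries something other than a carbon substituent: nitro, with 3 heavy atoms and 2 hydrogen-bond acceptors where methyl has none. Even so, the result is a 1.4-fold higher number from compound 1 to compound 4 (0.15 log units; within the scatter) and, against the ethyl group, a 1.4-fold lower number from compound 3 to compound 4 (0.13 log units; within the scatter), so neither exchange at this position reaches beyond the scatter. Compound 4 also stays within the scatter of the meta-methyl analogue, at a 1.7-fold higher number from compound 2 to compound 4 (0.22 log units; within the scatter), which leaves the step between compound 2 and compound 3 as the only one beyond it.

From the compounds shown here alone, whether an amine, a carboxylic acid or a longer alkyl chain at this position would stay equally close remains open. So does whether nitro would behave the same way on another carbon of this ring. No evidence is available to explain these steps.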